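This account rests on a few compounds, and the source may have more. Where it says the series, first, only, none or still open, it means among the compounds named here.

In a functional assay on SK-N-SH cells (Homo sapiens) for inhibition, read by MTT assay, with a stated time of 72 h, tested at 50 uM (a higher number here means more inhibition of growth at the concentration tested, a lower number less inhibition of growth), compound 1 (`C=CCc1cc(O)c(O)c(CN2CCC(C)CC2)c1`) gives 84.2% and compound 2 (`C=CCc1ccc(OCc2cn(-c3ccc(C#N)cc3)nn2)c(O)c1`) gives 62.5% as the lower of the two numbers, with a gap between them that lies beyond the scatter. Compound 3 (`C=CCc1ccc(OCc2cn(-c3ccc(OC)cc3)nn2)c(O)c1`) has not been measured yet and differs from compound 2 by methoxy in place of cyano on an aromatic carbon. Within the data shown here, no measured step shows what this exchange does, so in this assay no change beyond the scatter is expected in either direction (a number 2.5 percentage points lower from compound 2 to compound 3 (within the scatter)). For compound 3 the estimate is 60% (expected range 42% to 78%).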

Compound 3, percent growth inhibition at one concentration: 68.5%
Compound 3: middle estimate off by 8.5 percentage points, on the low side; the range from low to high includes it.
By their numbers in this assay, from the lowest: compounds 2 and 3 (each within the scatter of the next); then compound 1.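

In this assay, among these compounds, the change from 4-cyanophenyl to 4-methoxyphenyl gives a number 6 percentage points higher from compound 2 to compound 3 (within the scatter) and is the first measured step at this place, on an aromatic carbon para to a large group. At this position, then, cyano and methoxy cannot be told apart in this test of growth inhibition. Nothing available explains this result. Still open, going by these compounds, is whether an amine or a carboxylic acid at this place, or a longer chain in place of methoxy, would shift the number beyond the scatter. Whether the same exchange behaves alike on another core is also unknown.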